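A lactam replaces the oxazolylamino group: expected clearance

The source may hold more compounds than are shown below. What is called first, only, known or untested is meant among the compounds shown, and "the series" means these compounds.

Three compounds were measured in an ADME assay on microsomes from liver (Homo sapiens) for metabolic stability, read by LC-MS, using NADPH, with stated times of 5 min and 30 min, tested at 1 uM; on this read-out lower numbers stand for slow clearance and higher numbers for fast clearance:
compound 1 `CN(c1ncco1)c1cnc(NCc2c(F)ccc3c2CCO3)n2cnnc12` gives 11 mL.min-1.g-1
compound 2 `Cc1ncc(-c2cnc(NCc3c(F)ccc4c3CCO4)c3cn[nH]c(=O)c23)n1C` gives 10 mL.min-1.g-1
compound 3 `CNC(=O)c1ncc(-c2cnc(NCc3c(F)ccc4c3CCO4)c3cn[nH]c(=O)c23)n1C` gives 24 mL.min-1.g-1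

Compound 1 stands second highest of the three; compound 2 sits within the scatter of it, while compound 3 lies beyond the scatter above it. For the measured compounds named here, the single measured step, a 2.4-fold higher number from compound 2 to compound 3 (0.38 log units; beyond the scatter), concerns a different change on a different core. Compound 4 `O=C1CCCN1c1cnc(NCc2c(F)ccc3c2CCO3)n2cnnc12` differs from compound 1 as follows: 2-oxopyrrolidin-1-yl in place of methyl(1,3-oxazol-2-yl)amino on an aromatic carbon. Going by the values given here, no measured step touches this change, and the numbers give no direction for it; the expected step of a 1.1-fold lower number from compound 1 to compound 4 (0.04 log units; within the scatter) is therefore set close to compound 1 and within the scatter, with a wide range. Compound 4 is expected to give 10 mL.min-1.g-1 in this assay, between 4 mL.min-1.g-1 and 24 mL.min-1.g-1.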

Compound 4, intrinsic clearance in microsomes: < 3 mL.min-1.g-1
Compound 4: a limit, no number (the forecaster's own chance of this, stated with the estimate: 5%); middle value at least 3.3-fold (0.52 log units) from the limit.
By their numbers in this assay, from the lowest: compounds 2 and 1 (each within the scatter of the next); then compound 3. At a limit, below all of these: compound 4.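

On the shared core, 2-oxopyrrolidin-1-yl in place of methyl(1,3-oxazol-2-yl)amino gives an at least 3.6-fold lower number from compound 1 to compound 4 (0.56 log units; beyond the scatter). For the compounds shown here, this is the first measured sign that the group on this aromatic carbon moves the read-out in this assay, and the lactam ring sits on the slow-clearance side. The value of compound 4 is a limit and not a number, so the full size of the step stays unknown: the limit of < 3 mL.min-1.g-1 in this assay, at which 1 of the 4 values shown sits.

With a single pair at this position, the data cannot separate the part played by the ring from that of the carbonyl. On these data alone, how a dimethylamino group or a six-membered lactam on this carbon would read remains open.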